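A hydroxy group added to compound 1

The source may report more compounds than this note shows. Statements on the series, on what has been measured and on what is new or still open speak of the compounds shown alone.

Measured in an ADME assay on L6 cells (Rattus norvegicus) for cytotoxicity; on this read-out lower numbers stand for stronger inhibition and higher numbers for weaker inhibition:
- compound 1 `N=C(N)c1cccc(-c2cc3ccc(C(=N)N)cc3o2)c1`: 131000 nM
- compound 2 `c1cc(C2=NCCN2)cc(-c2cc3ccc(C4=NCCN4)cc3o2)c1`: 12800 nM
- compound 3 `COc1cc(C(=N)NC(C)C)ccc1-c1cc2cc(C(=N)NC(C)C)ccc2o1`: 98100 nM

Compound 1 and compound 3 sit together at the high end of this small set, within the scatter of each other. Compound 2 lies beyond the scatter on the lower side of compound 1, which means stronger inhibition.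

The next compound to be tested is compound 4 `N=C(N)c1ccc(O)c(-c2cc3ccc(C(=N)N)cc3o2)c1`. It differs from compound 1 by hydroxy in place of hydrogen on an aromatic carbon. Within the data shown here, no measured pair shows what this kind of change does in this assay, so the expectation rests on the starting point, compound 1 at 131000 nM, and on the spread of the three values. A small move toward a lower number is expected, one that stays within the scatter. The estimated step is a 1.5-fold lower number from compound 1 to compound 4 (0.16 log units; within the scatter). For compound 4 the expected value is 90000 nM, with an estimated range of 30000 nM to 200000 nM.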

Compound 4, half-maximal inhibitory concentration: 164000 nM
The estimate for compound 4 lay 1.8-fold (0.26 log units) below the measured number, and the stated range covers the measured number.
By their numbers in this assay, from the lowest: compound 2; then compounds 3, 1 and 4 (each within the scatter of the next).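

In this assay, among these compounds, hydroxy in place of hydrogen on an aromatic carbon, ortho to a large group and para to a group of 3 heavy atoms, gives a 1.3-fold higher number from compound 1 to compound 4 (0.10 log units; within the scatter) and so provides the first one-place comparison in this set. At this position, the added hydroxy therefore produces no change that can be told apart from the scatter, and the two compounds remain together at the high end of the read-out. Nothing available explains this outcome.

The compounds shown leave open whether an amine or a carboxylic acid on the same carbon would also stay within the scatter of compound 1. This single step also cannot show whether hydroxy would behave the same way on the core of compound 2 or compound 3.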